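A few compounds are considered here, and "the series" means these few. Any claim that something is new, unique, unknown or untested is made for them only; others in the source may bear on it.

Of the compounds shown here, three of a shared core have been measured in a functional assay on HOP-62 cells (Homo sapiens) for cytotoxicity, read by sulforhodamine B assay, with a stated time of 48 h; on this read-out lower numbers stand for higher toxicity in this test and higher numbers for lower toxicity in this test. Compound 1 `ClCc1ccc(Cn2cnc3nc(Cl)nc(Cl)c32)cc1` gives 7940 nM. Compound 2 `ClCc1cccc(Cn2cnc3nc(Cl)nc(Cl)c32)c1`, which carries the chloromethyl group on the other position of the benzyl ring, gives 6020 nM in this assay, a number within the usual scatter of that of compound 1, so the two cannot be told apart. Compound 3 `Nc1nc(Cl)c2ncn(Cc3cccc(CCl)c3)c2n1` carries an amino group where compound 1 and compound 2 carry a chloro group. In this assay compound 3 gives 58900 nM. On the numbers shown, compound 1 therefore stands second highest of the three, with compound 2 closest to it and compound 3 furthest away, beyond the scatter.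

Compound 4 `ClCc1ccc(Cn2cnc3ncnc(Cl)c32)cc1` has not yet been measured in this assay. It differs from compound 1 in one place: hydrogen in place of chloro on an aromatic carbon, the carbon that sits between two ring nitrogen atoms of the six-membered ring of the fused system. Among the measured compounds shown here, no measured pair shows this exact change. Since the other compound without a chloro group at that place, compound 3, gives the higher number 58900 nM, compound 4 is expected to give a somewhat higher number than compound 1, by a step of a 2.0-fold higher number from compound 1 to compound 4 (0.30 log units; within the scatter). The estimate for compound 4 in this assay is 16000 nM, in a range from 5000 nM to 50000 nM.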

Compound 4, concentration lethal to 50% of the cells: 5620 nM
The estimate for compound 4 lay 2.8-fold (0.45 log units) above the measured number, within the range that was stated.
By their numbers in this assay, from the lowest: compounds 4, 2 and 1 (each within the scatter of the next); then compound 3.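

In this assay, hydrogen in place of chloro on the aromatic carbon between two ring nitrogen atoms gives a 1.4-fold lower number from compound 1 to compound 4 (0.15 log units; within the scatter), so this pair cannot be told apart. Among the compounds shown here, this is the first direct reading of the change at this position, which the earlier compounds could not give, as none of them formed a pair with this single difference. It shows that, with the para chloromethyl group on the benzyl ring and the other chloro group both held in place, the chloro group at this carbon is not needed for the number that compound 1 gives in this test, and no measurement shown here offers an explanation for this result.

The compounds shown leave open whether a larger group on this same carbon, such as a methoxy group, a nitrile or a longer chain, would also leave the number unchanged or would move it beyond the scatter. They also leave open what happens when the chloro group that compound 4 retains gives way to hydrogen, since no pair shown isolates that change.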